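Swapping the 4-Hydroxyphenyl Group of Compound 2

This account rests on a few compounds, and the source may have more. Where it says the series, first, only, none or still open, it means among the compounds named here.

Within the data shown here, compound 2 `Oc1ccc(/C=N/N(Cc2ccccc2)Cc2ccccc2)cc1` holds the lowest of the two numbers so far obtained in an assay on liver (Sus scrofa) for inhibition of glucose-6-phosphatase catalytic subunit 1 (Homo sapiens), using microsomes; on this read-out higher numbers stand for weaker inhibition and lower numbers for stronger inhibition: compound 2 gives 2400 nM. Its nearest neighbour is compound 1 `C/C(=N\N(Cc1ccccc1)Cc1ccccc1)c1ccccc1`, which in this assay gives 25000 nM, a gap that lies beyond the scatter. Compound 3 `Clc1cc(Cl)cc(/C=N/N(Cc2ccccc2)Cc2ccccc2)c1` reaches only a limit in this assay, reported as > 100000 nM. Among the measured compounds shown here, the step of an at least 41-fold higher number from compound 2 to compound 3 (1.61 log units; beyond the scatter) is the one measured change at the carbon with the double bond to nitrogen, and it sits at the limit of > 100000 nM in this assay, at which 1 of the 3 values shown sits.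

Compound 4 `OCc1ccc(/C=N/N(Cc2ccccc2)Cc2ccccc2)o1` has not yet been measured. It differs from compound 2 in one place: 5-(hydroxymethyl)furan-2-yl in place of 4-hydroxyphenyl on a carbon with a double bond to nitrogen. For the measured compounds named here, the only measured step bearing on this position is the one from compound 2 to compound 3, and that step was large and upward. Compound 4, however, retains one hydrogen-bond donor and carries two hydrogen-bond acceptors, whereas compound 3 lost the donor entirely. A rise smaller than that seen for compound 3 is therefore expected, so the step of a 2.5-fold higher number from compound 2 to compound 4 (0.40 log units; beyond the scatter) is estimated as a moderate weakening. For compound 4 the expected value in this assay is 6000 nM, within a range from 1500 nM to 25000 nM.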

Compound 4, half-maximal inhibitory concentration: 16000 nM
For compound 4 the middle estimate is 2.7-fold (0.43 log units) below the measured one; low and high end bracket the measured number.
By their numbers in this assay, from the lowest: compound 2; then compounds 4 and 1 (each within the scatter of the next). At a limit, above all of these: compound 3.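

In this assay the replacement gives a 6.7-fold higher number from compound 2 to compound 4 (0.82 log units; beyond the scatter), so 5-(hydroxymethyl)furan-2-yl on the carbon with a double bond to nitrogen falls short of 4-hydroxyphenyl, even though both groups count 1 hydrogen-bond donor; keeping that count does not by itself hold the number of compound 2. Set against the 3,5-dichlorophenyl group, the same entering group gives an at least 6.2-fold lower number from compound 3 to compound 4 (0.79 log units; beyond the scatter), the first sign that a group other than 4-hydroxyphenyl at this position can return a measured number in this series. The end of that step at compound 3 is a limit and not a number, so the size of the step stays open upward: the limit of > 100000 nM in this assay, at which 1 of the 4 values shown sits.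

The compounds shown leave open whether the step from 4-hydroxyphenyl comes from the change to a five-membered aromatic ring or from the hydroxymethyl group, as the two change together in compound 4. Also open, on these data alone, is how the position would respond to an unsubstituted phenyl, a furan-2-yl without the hydroxymethyl group, or a carboxylic acid or an amine in the place of that hydroxyl.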